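The compounds below may be only part of what the source reports. "The series", "measured", "known", "first", "only" and "open" are said of these compounds alone.

The study concerns three measured compounds and one still to be tested, all built on the same shared core. In a functional assay for inhibition, with Homo sapiens as the target (a lower number here means a stronger inhibitor, a higher number a weaker inhibitor), compound 1 `CNc1nncc2cncn12` gives only a limit of the assay, > 48000 nM. In this assay compound 2 `CC(C)c1ncn2c(O)nncc12` likewise reaches only a limit, > 48000 nM. In this assay compound 3 `Cc1ncc2cnnc(O)n12` also stands at a limit, > 48000 nM. Compound 3 therefore cannot be placed above or below its companions, as all three values rest at the limit of > 48000 nM in this assay, at which 3 of the 3 values shown sit. Within the data shown here, no step between measured compounds with a single change is available, so no measured size of effect can be drawn on.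

Compound 4 `Oc1nncc2cncn12` differs from compound 3 by hydrogen in place of methyl on an aromatic carbon. The expected step in this assay is a step that the limit leaves unreadable from compound 3 to compound 4, none beyond the scatter. For compound 4 the estimate in this assay is 60000 nM, expected to fall between 20000 nM and 200000 nM, with the assay most likely to report only a limit again.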

Compound 4, half-maximal inhibitory concentration: > 48000 nM
Compound 4 was reported as a limit (the forecaster's own chance of this, stated with the estimate: 85%); the middle value does not contradict the limit.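

Compound 4 stands at a limit in this assay, as do compound 1, compound 2 and compound 3, so no step from any of them to compound 4 can be read: the limit of > 48000 nM in this assay, at which 4 of the 4 values shown sit.

The compounds shown leave open whether any group on the shared core changes inhibition in this assay, and by how much.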